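Swapping the Ring on the Amide Nitrogen

The compounds below may be only part of what the source reports. "The series", "measured", "known", "first", "only" and "open" are said of these compounds alone.

Compound 1 `CC1SC(c2cccc(C(=O)NCCCCc3ccccc3)c2)N(c2ccc(C3CC3)cc2)C1=O` is tested in a functional assay on HOS-TE85 cells (Homo sapiens) for inhibition, read by CCK-8 assay, with a stated time of 72 h (on this read-out higher numbers stand for weaker inhibition and lower numbers for stronger inhibition), where compound 1 gives 191 nM. Compound 2 `O=C(NCCCCc1ccccc1)c1cccc(C2SCC(=O)N2c2cccc(-c3c[nH]nn3)c2)c1` gives 110 nM in this assay; these two values lie within the scatter of each other, so neither compound can be called the stronger inhibitor. Compound 3 `COc1ccccc1N1C(=O)C(C)SC1c1cccc(C(=O)NCCCCc2ccccc2)c1` differs from compound 1 by 2-methoxyphenyl in place of 4-cyclopropylphenyl on an amide-type nitrogen in a ring. Among the measured compounds shown here, no measured pair shows this exact change, so its effect is unknown; the step of a 1.3-fold higher number from compound 1 to compound 3 (0.10 log units; within the scatter) is expected to be small, at most within the scatter. Compound 3 is therefore expected to give about 240 nM, between 80 nM and 750 nM.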

Compound 3, half-maximal inhibitory concentration in the HOS-TE85 assay: 45.1 nM
For compound 3 the middle estimate is 5.3-fold (0.73 log units) above the measured one, and the stated range ends above it.
By their numbers in the HOS-TE85 assay, from the lowest: compound 3; then compounds 2 and 1 (each within the scatter of the next).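

This position on the amide-type nitrogen in a ring clearly matters: in the HOS-TE85 assay, 2-methoxyphenyl in place of 4-cyclopropylphenyl gives a 4.2-fold lower number from compound 1 to compound 3 (0.63 log units; beyond the scatter). In a physicochemical assay for solubility, read by turbidimetry, measured as kinetic solubility, at pH 7.4 (on this read-out higher numbers stand for higher solubility and lower numbers for lower solubility), compound 1 gives 2000 nM and compound 3 gives 10000 nM. This single change therefore pairs stronger inhibition with higher solubility: the measured solubility of compound 1, 2000 nM, and of compound 3, 10000 nM, a 5.0-fold higher number (0.70 log units; beyond the scatter).

Among the compounds shown here, with only this one swap, the compounds cannot separate the effect of gaining the methoxy group from that of losing the cyclopropyl group. From the compounds shown here alone, how an amine or a carboxylic acid on this phenyl ring would behave also remains open.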